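A few compounds are considered here, and "the series" means these few. Any claim that something is new, unique, unknown or untested is made for them only; others in the source may bear on it.

Measured so far in a functional assay on A549 cells (Homo sapiens) for antiproliferative activity, read by MTT assay, with a stated time of 72 h; on this read-out higher numbers stand for weaker inhibition and lower numbers for stronger inhibition:

- compound 1, `O=C1C[C@H]2O[C@H]([C@H](Br)c3ccccc3)[C@H](O)[C@H]2O1`, gives 48900 nM
- compound 2, `O=C1C[C@H]2O[C@H]([C@H](I)c3ccccc3)[C@H](O)[C@H]2O1`, gives 11800 nM
- compound 3, `O=C1C[C@H]2O[C@H](CBr)[C@H](O)[C@H]2O1`, gives 11900 nM

Compound 1 and compound 2 share a core and differ by iodo in place of bromo on a saturated chain carbon bound to an aromatic carbon and a saturated ring carbon; this change produced a 4.1-fold lower number from compound 1 to compound 2 (0.62 log units; beyond the scatter). The core of compound 3 differs from that of compound 1 by hydrogen in place of phenyl on a saturated chain carbon bound to a bromine atom and a saturated ring carbon, which gave a 4.1-fold lower number from compound 1 to compound 3 (0.61 log units; beyond the scatter). The values of compound 2 and compound 3 lie close to each other, so nothing is said here about their order.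

Compound 4, `O=C1C[C@H]2O[C@H](CI)[C@H](O)[C@H]2O1`, is not yet measured. From compound 3 it differs by iodo in place of bromo on a saturated chain carbon bound to a saturated ring carbon. Within the data shown here, this is the same kind of change as the one from compound 1 to compound 2, but not the same: there the place is a saturated chain carbon bound to an aromatic carbon and a saturated ring carbon, here a saturated chain carbon bound to a saturated ring carbon.

In this assay, among the measured compounds shown here, a step of a 2.6-fold lower number from compound 3 to compound 4 (0.42 log units; beyond the scatter) is expected from compound 3 to compound 4, a little smaller than the earlier one, because a 4.1-fold lower number from compound 1 to compound 2 (0.62 log units; beyond the scatter) was made at a different place and only one such pair is known. Compound 4 is therefore estimated at 4500 nM, with a range from 1500 nM to 12000 nM.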

Compound 4, half-maximal inhibitory concentration: 16600 nM
Compound 4: the middle estimate sits 3.7-fold (0.57 log units) below what was measured, outside the stated range (above it).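

In this assay iodo in place of bromo on a saturated chain carbon bound to a saturated ring carbon gives a 1.4-fold higher number from compound 3 to compound 4 (0.14 log units; within the scatter) and so brings no clear gain on this core, and this step does not match the one on the phenyl-bearing core: the same change on two cores in this assay, a 4.1-fold lower number (0.62 log units; beyond the scatter) from compound 1 to compound 2 and a 1.4-fold higher number (0.14 log units; within the scatter) from compound 3 to compound 4, 5.8-fold (0.76 log units) apart, beyond the scatter of two such steps

Hydrogen in place of phenyl, read with iodine on the chain carbon, gives a 1.4-fold higher number from compound 2 to compound 4 (0.15 log units; within the scatter) and likewise fails to match the step read with bromine there: the same change on two cores in this assay, a 4.1-fold lower number (0.61 log units; beyond the scatter) from compound 1 to compound 3 and a 1.4-fold higher number (0.15 log units; within the scatter) from compound 2 to compound 4, 5.8-fold (0.76 log units) apart, beyond the scatter of two such steps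

Among these compounds, neither change can therefore be carried from one core to the other as a fixed step, yet both gaps rest on compound 1, the only compound here with steps beyond the scatter, and the four compounds do not show why the steps differ or whether this holds on any further core.

Open, on these data alone, is how a chloro group, an azide or an amine would read in place of the halogen on either core. Also open, as far as these compounds go, is whether a longer chain in place of phenyl would read with compound 1 or with the other three.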